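Chain extension by one methyl: cytotoxicity notes

The source may report more compounds than this note shows. Statements on the series, on what has been measured and on what is new or still open speak of the compounds shown alone.

Compound 1 `CCCCCCCCCCn1cc(-c2nc3ccccc3cc2CCCC)nn1` belongs to a small set of three analogues on a shared core, all examined in a functional assay on HeLa cells (Homo sapiens) for cytotoxicity, read by MTT assay, with a stated time of 24 h; a higher number here means a weaker inhibitor, a lower number a stronger inhibitor. In this assay compound 1 returns only a limit, > 100 ug/mL, so no number is known for it. Compound 2 `CCCCCc1cc2ccccc2nc1-c1cn(CCC(F)(F)C(F)(F)C(F)(F)C(F)(F)C(F)(F)C(F)(F)C(F)(F)C(F)(F)F)nn1` likewise returns a limit in this assay, > 100 ug/mL. Compound 3 `CCc1cc2ccccc2nc1-c1cn(-c2ccc(F)cc2)nn1` also sits at a limit in this assay, > 100 ug/mL. Among the compounds with values here, the measured picture therefore consists entirely of the limit of > 100 ug/mL in this assay, at which 3 of the 3 values shown sit, and no step between measured compounds can be sized; where compound 1 stands is known only as being at that limit.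

Compound 4 `CCCCCCCCCCn1cc(-c2nc3ccccc3cc2CCCCC)nn1` differs from compound 1 by methyl in place of hydrogen on a saturated chain carbon, four bonds along the chain from an aromatic carbon. Within the data shown here, with no measured step available, no movement beyond the usual scatter is expected in this assay, since every measured analogue sits at the limit of > 100 ug/mL in this assay, at which 3 of the 3 values shown sit. Compound 4 is accordingly expected to return a limit as well, estimated at 150 ug/mL with a range from 60 ug/mL to 400 ug/mL. The implied step that the limit leaves unreadable from compound 1 to compound 4 is expected to be nothing beyond the scatter.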

Compound 4, half-maximal inhibitory concentration: > 100 ug/mL
Compound 4: only a limit was reported; the forecaster's own chance of this, stated with the estimate: 85%; the middle value is on the limit's open side.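

Compound 4 in this assay returns > 100 ug/mL as a limit, not a number. Within the data shown here, compound 1 also stands at a limit, so no step between compound 1 and compound 4 can be read. The compounds shown leave open whether any change on the shared core brings a value within reach in this assay at all.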